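The compounds below may be only part of what the source reports. "The series", "measured", "known", "first", "only" and "open" are said of these compounds alone.

Measured so far:
Compound 1 `C#Cc1cccc(Nc2ncnc3cc(OC)c(OCCCCCN/C(=N\C#N)Nc4ccncc4)cc23)c1`: 38 nM
Compound 2 `C#Cc1cccc(Nc2ncnc3cc(OC)c(OCCCCCCN/C(=N\C#N)Nc4ccncc4)cc23)c1`: 7.47 nM

Both compounds were tested in a functional assay on MCF7 cells (Homo sapiens) for inhibition, read by CCK-8 assay, with a stated time of 72 h; a lower number here means a stronger inhibitor of growth, a higher number a weaker inhibitor of growth. Of the two numbers, the higher belongs to compound 1 at 38 nM, and the gap down to compound 2 at 7.47 nM lies beyond the scatter. Compound 3 `C#Cc1cccc(Nc2ncnc3cc(OC)c(OCCCCCN/C(=N\C#N)Nc4cccnc4)cc23)c1`, still to be measured in this assay, has the same atoms as compound 1, joined differently. It carries pyridin-3-yl in place of pyridin-4-yl on an amine nitrogen. Going by the values given here, no measured pair isolates this change, so the data offer no direct guide to its size or direction. The expectation is therefore no step beyond the scatter, with the expected step being a 1.2-fold higher number from compound 1 to compound 3 (0.07 log units; within the scatter). For compound 3 the estimated value is 45 nM, within an expected range from 12 nM to 170 nM.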

Compound 3, concentration for 50% growth inhibition: 175 nM
Compound 3: middle estimate off by 3.9-fold (0.59 log units), on the low side, outside the stated range (above it).
By their numbers in this assay, from the lowest: compound 2; then compound 1; then compound 3.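

In this assay, putting pyridin-3-yl in place of pyridin-4-yl on the amine nitrogen gives a 4.6-fold higher number from compound 1 to compound 3 (0.66 log units; beyond the scatter), a step beyond the scatter. Compounds 1 and 2 both carry pyridin-4-yl, so they could not show that this position responds to an exchange of one pyridinyl isomer for another, even with the atom count unchanged and the rest of the molecule identical. Nothing at hand accounts for the direction or size of this step.

Going by these compounds, it remains open whether the same exchange would have a similar effect on the longer chain of compound 2, since this step has been read on only one chain. On these data alone, it is also open how pyridin-2-yl or an unsubstituted phenyl ring on the same amine nitrogen would compare with pyridin-4-yl.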